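Methyl on the benzyl group, compound 2 to compound 3

The compounds below may be only part of what the source reports. "The series", "measured", "known", "first", "only" and "open" are said of these compounds alone.

For the measured compounds named here, compound 2 `COc1cc(-c2nc3cc(/C=C4\SC(=O)N(Cc5ccccc5)C4=O)ccc3[nH]2)cc(OC)c1OC` carries a benzyl group on the amide-type ring nitrogen; in a functional assay on PC-3 cells (Homo sapiens) for inhibition, read by MTT assay, with a stated time of 48 h (on this read-out higher numbers stand for weaker inhibition and lower numbers for stronger inhibition), compound 2 gives 2500 nM, the lowest of the two numbers so far. Going by the values given here, compound 1 `COc1cc(-c2nc3cc(/C=C4\SC(=O)N(CC(=O)N5CCCCC5)C4=O)ccc3[nH]2)cc(OC)c1OC` carries a (piperidin-1-yl)carbonyl on the same chain carbon and in this assay compound 1 gives 14700 nM; the step of a 5.9-fold lower number from compound 1 to compound 2 (0.77 log units; beyond the scatter) is the only measured step. Compound 3 `COc1cc(-c2nc3cc(/C=C4\SC(=O)N(Cc5cccc(C)c5)C4=O)ccc3[nH]2)cc(OC)c1OC` differs from compound 2 by methyl in place of hydrogen on an aromatic carbon. Among the compounds with values here, no measured step touches a substituent on the phenyl of the benzyl group: the one step swapped the whole group on the chain carbon, not a ring hydrogen, so it gives no guide to this change. The number in this assay is expected to move little, within the scatter, with no preferred direction. Compound 3 is estimated at 2500 nM (range 1000 nM to 6500 nM), an expected step of no change at the digits printed from compound 2 to compound 3 (within the scatter) that stays within scatter.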

Compound 3, half-maximal inhibitory concentration: 4370 nM
Compound 3: the middle estimate sits 1.7-fold (0.24 log units) below what was measured; the measured number falls inside the stated range.
By their numbers in this assay, from the lowest: compounds 2 and 3 (each within the scatter of the next); then compound 1.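

In this assay a methyl on the phenyl of the benzyl group gives a 1.7-fold higher number from compound 2 to compound 3 (0.24 log units; within the scatter) and so this aromatic carbon takes a methyl with no change beyond the scatter. The lower number relative to the (piperidin-1-yl)carbonyl compound also holds with the methyl present, at a 3.4-fold lower number from compound 1 to compound 3 (0.53 log units; beyond the scatter) and so in these compounds it does not rest on the phenyl being unsubstituted. No supporting evidence bears on either step.

A single methyl at one ring position leaves open whether a chlorine, an amine or a carboxylic acid on that phenyl would move the number beyond the scatter. Also open, going by these compounds, is how a longer chain carrying the phenyl on the ring nitrogen would read in this assay.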